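Inverting one ring stereocentre of compound 2

The compounds below may be only part of what the source reports. "The series", "measured", "known", "first", "only" and "open" are said of these compounds alone.

Compound 1 `O=C(O)[C@@H]1NCC=C[C@H]1O` and compound 2 `O=C(O)[C@H]1NCC=C[C@@H]1O` share all atoms and bonds and differ only in configuration. In an assay for inhibition of alpha-N-acetylgalactosaminidase (Gallus gallus), tested at 1000 uM (on this read-out lower numbers stand for less inhibition and higher numbers for more inhibition at the one concentration tested (going by the name of the read-out)), compound 1 gives 3.2% and compound 2 gives 25%; compound 2 stands highest of the two numbers, with compound 1 as the nearest and lower. Within the data shown here, the step of a number 21.8 percentage points higher from compound 1 to compound 2 (beyond the scatter) is the only measured step in the set, and it rests on (the fact that compounds 1 and 2 differ only in the configuration as drawn).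

Compound 3 `O=C(O)[C@H]1NCC=C[C@H]1O` is not yet measured in this assay. It differs from compound 2 in this way: the two compounds have the same atoms and bonds and differ only in configuration as drawn: 1 of 2 stereo elements differ; a stereocentre at a saturated ring carbon is drawn S in compound 2 and R in compound 3. Of the measured steps only the inversion from compound 1 to compound 2 bears on it, and there both stereocentres were inverted at once, giving the modest gain a number 21.8 percentage points higher from compound 1 to compound 2 (beyond the scatter); here only one of the two is inverted, so compound 3 is the mirror image of neither compound 1 nor compound 2. Among the measured compounds shown here, no measured pair isolates a single stereocentre. Compound 3 is thus expected to land between the two measured numbers, a change of a number 13 percentage points lower from compound 2 to compound 3 (beyond the scatter), most likely a modest drop that may not exceed the scatter. The estimate for compound 3 in this assay is 12%, with a range from 0% to 35%.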

Compound 3, a percentage reported as inhibition, at one concentration (the size of the read-out at that concentration, not a potency): 0.2%
Estimate against measurement, compound 3: 11.8 percentage points above; low and high end bracket the measured number.
By their numbers in this assay, from the lowest: compounds 3 and 1 (each within the scatter of the next); then compound 2.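

In this assay, inverting a single stereocentre of compound 2 is enough to remove most of its reading: a number 24.8 percentage points lower from compound 2 to compound 3 (beyond the scatter), with one saturated ring carbon going from S to R. Inverting the other stereocentre gives a different picture: a number 3 percentage points lower from compound 1 to compound 3 (within the scatter), with one saturated ring carbon going from R to S. Among these three stereoisomers, only compound 2 stands beyond the scatter of the other two, so the reading depends on the full configuration of compound 2 rather than on either stereocentre alone, and configuration is the only structural variable here: the fact that compounds 2 and 3 differ only in the configuration as drawn

These compounds leave open how the remaining combination of the two stereocentres reads, and how compound 2 behaves at any concentration other than the single one tested. They also leave open whether a methyl ester in place of the carboxylic acid, or an amine in place of the hydroxyl, would retain any reading with the configuration of compound 2 kept.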